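A few compounds are considered here, and "the series" means these few. Any claim that something is new, unique, unknown or untested is made for them only; others in the source may bear on it.

Measured so far:
- compound 1, `O=C(N/N=C/c1cccc(Cl)c1)c1cccnc1Nc1cccc(C(F)(F)F)c1`, with 76.7%
- compound 2, `O=C(N/N=C/c1ccc(Cl)cc1)c1cccnc1Nc1cccc(C(F)(F)F)c1`, with 67.2%
- compound 3, `O=C(N/N=C/c1ccc(O)cc1)c1cccnc1Nc1cccc(C(F)(F)F)c1`, with 70.5%

These three compounds were tested in a functional assay on the whole organism (strain Wistar) for inhibition, with Rattus norvegicus as the target, read by paw edema, with a stated time of 1 h, at a dose of 10 mg/kg by the intraperitoneal route; on this read-out lower numbers stand for less inhibition and higher numbers for more inhibition at the one dose given (going by the name of the read-out). Compound 1 gives the largest number of the three, yet its two steps to the others are both within the scatter: a number 9.5 percentage points lower from compound 1 to compound 2 (within the scatter) and a number 6.2 percentage points lower from compound 1 to compound 3 (within the scatter). Compound 2 and compound 3 likewise sit close together, a number 3.3 percentage points higher from compound 2 to compound 3 (within the scatter). So far the three compounds are indistinguishable on this read-out.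

Compound 4, `COc1ccc(/C=N/NC(=O)c2cccnc2Nc2cccc(C(F)(F)F)c2)c(OC)c1`, has not yet been measured in this assay. It differs from compound 1 in one place: 2,4-dimethoxyphenyl in place of 3-chlorophenyl on a carbon with a double bond to nitrogen

For the measured compounds named here, no measured step introduces a 2,4-dimethoxyphenyl group, so no step bears directly on this change. The two steps that do replace the 3-chlorophenyl group of compound 1, a number 9.5 percentage points lower from compound 1 to compound 2 (within the scatter) and a number 6.2 percentage points lower from compound 1 to compound 3 (within the scatter), were both within the scatter, which gives no reason to expect a step beyond the scatter here either. Compound 4 is therefore expected to give 70% in this assay, with a range from 55% to 85%. The expected step is a number 6.7 percentage points lower from compound 1 to compound 4 (within the scatter).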

Compound 4, a percentage reported as inhibition, in the whole organism at one dose (the size of the read-out at that dose, not a potency): 55.7%
Beside the measured number, compound 4's estimate is 14.3 percentage points above it, and the stated range covers the measured number.
By their numbers in this assay, from the lowest: compound 4; then compounds 2, 3 and 1 (each within the scatter of the next).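

In this assay, the position on a carbon with a double bond to nitrogen turned out to be able to shift the number beyond the scatter, which no earlier replacement there had done: 2,4-dimethoxyphenyl gives steps of this kind against all three other groups (a number 21 percentage points lower from compound 1 to compound 4 (beyond the scatter); a number 14.8 percentage points lower from compound 3 to compound 4 (beyond the scatter); a number 11.5 percentage points lower from compound 2 to compound 4 (beyond the scatter)). Compound 4 therefore stands alone as the lowest of the four, while compounds 1, 2 and 3 stay within the scatter of their neighbours, so the change separates this one group from the 3-chlorophenyl, 4-chlorophenyl and 4-hydroxyphenyl groups, and none of the compounds shown goes against that. No measurement shown bears on what lies behind this drop.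

Compound 4 carries two methoxy groups on its phenyl ring, so the compounds shown leave open whether a single methoxy group would give a similar number or whether both are needed. Also open, from the compounds shown here alone, is what an amine or a carboxylic acid on that phenyl ring would give, and whether the gap seen here would hold at other doses or stated times.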